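Swapping chlorinated quinoline for bare quinoline in a diterpenoid lactone

The source may report more compounds than this note shows. Statements on the series, on what has been measured and on what is new or still open speak of the compounds shown alone.

Of the compounds shown here, three have been tested in an ADME assay on SNB-19 cells (Homo sapiens) for cytotoxicity, read by MTT assay, with a stated time of 24 h; a higher number here means that more compound is tolerated, a lower number that less compound is tolerated. Compound 1 `C=C1CC[C@@H]2[C@](C)(COC(C)=O)[C@H](O)CC[C@@]2(C)[C@@H]1C/C=C1/C(=O)OC[C@@H]1Oc1cccc2cccnc12` gives 49500 nM. Compound 2 `C=C1CC[C@@H]2[C@](C)(COC(C)=O)[C@H](O)CC[C@@]2(C)[C@@H]1C/C=C1/C(=O)OC[C@@H]1Oc1c(Cl)cc(Cl)c2cccnc12` gives 39300 nM. Compound 3 `C=C1CC[C@H]2[C@@](C)(CCC(=O)[C@@]2(C)COC(C)=O)[C@@H]1C/C=C1/C(=O)OC[C@@H]1Oc1c(Cl)cc(Cl)c2cccnc12` gives 72000 nM. The move from compound 2 to compound 1 is quinolin-8-yl in place of 5,7-dichloroquinolin-8-yl on an oxygen on a saturated carbon, and the measured step is a 1.3-fold higher number from compound 2 to compound 1 (0.10 log units; within the scatter). The difference between the cores of compound 3 and compound 2 is not broken down here. Compound 4 `C=C1CC[C@H]2[C@@](C)(CCC(=O)[C@@]2(C)COC(C)=O)[C@@H]1C/C=C1/C(=O)OC[C@@H]1Oc1cccc2cccnc12` has not yet been measured; it arises from compound 3 by quinolin-8-yl in place of 5,7-dichloroquinolin-8-yl on an oxygen on a saturated carbon, the same change in the same surroundings. Because compound 2 to compound 1 gave a 1.3-fold higher number from compound 2 to compound 1 (0.10 log units; within the scatter), a step of similar size is expected from compound 3 to compound 4, namely a 1.2-fold higher number from compound 3 to compound 4 (0.09 log units; within the scatter). Compound 4 is therefore estimated at 88000 nM, with a likely range from 45000 nM to 170000 nM.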

Compound 4, half-maximal cytotoxic concentration: 21900 nM
Estimate against measurement, compound 4: 4.0-fold (0.60 log units) above; measured number below the stated range.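

In this assay, putting quinolin-8-yl in place of 5,7-dichloroquinolin-8-yl gave a 3.3-fold lower number from compound 3 to compound 4 (0.52 log units; beyond the scatter). So the change did not carry over from one core to the other with the same size or direction: the same change on two cores in this assay, a 1.3-fold higher number (0.10 log units; within the scatter) from compound 2 to compound 1 and a 3.3-fold lower number (0.52 log units; beyond the scatter) from compound 3 to compound 4, 4.1-fold (0.62 log units) apart, beyond the scatter of two such steps. This shows that, for these two cores, the outcome of the swap depends on the core it is made on, but it does not show which difference between the cores matters or how the swap would behave on a further core.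

The compounds shown also leave open what a quinoline bearing an amine or a carboxylic acid instead of chlorine would do on either core.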